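Swapping a dichlorophenyl for a dihydroxyphenyl on the hydrazone

The source may hold more compounds than are shown below. What is called first, only, known or untested is meant among the compounds shown, and "the series" means these compounds.

Measured compounds:
- compound 1 `Cc1cc(/C=N/NC(=O)Nc2ccc(Oc3ccnc(-c4nncn4CCN(C)C)c3)c(F)c2)cc(C)c1O`: 1220 nM
- compound 2 `CN(C)CCn1cnnc1-c1cc(Oc2ccc(NC(=O)N/N=C/c3ccc(F)cc3F)cc2F)ccn1`: 960 nM
- compound 3 `CN(C)CCn1cnnc1-c1cc(Oc2ccc(NC(=O)N/N=C/c3ccc(Cl)cc3Cl)cc2F)ccn1`: 390 nM

All three share one core and differ only in the aryl ring attached to the carbon with a double bond to nitrogen. In a functional assay on HT-29 cells (Homo sapiens) for cytotoxicity, read by MTT assay, with a stated time of 72 h (a higher number here means a weaker inhibitor, a lower number a stronger inhibitor), compound 3 gives 390 nM, the lowest number of the three; the step of a 3.1-fold lower number from compound 1 to compound 3 (0.50 log units; beyond the scatter) and the step of a 2.5-fold lower number from compound 2 to compound 3 (0.39 log units; beyond the scatter) both lie beyond the scatter, so compound 3 is the strongest inhibitor among the measured set.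

Compound 4 `CN(C)CCn1cnnc1-c1cc(Oc2ccc(NC(=O)N/N=C/c3ccc(O)cc3O)cc2F)ccn1` keeps that core and alters the same ring: 2,4-dihydroxyphenyl in place of 2,4-dichlorophenyl on a carbon with a double bond to nitrogen. The nearest guide is the step of a 3.1-fold lower number from compound 1 to compound 3 (0.50 log units; beyond the scatter), where a ring carrying a hydroxyl group gave way to the 2,4-dichlorophenyl; the present change runs the other way, removing both chlorines and putting in two hydroxyl groups. The step of a 2.5-fold lower number from compound 2 to compound 3 (0.39 log units; beyond the scatter) points the same way, with the halogen-bearing rings standing on the stronger side. A modest loss of potency is therefore expected.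

For compound 4 the expected result in this assay is 1300 nM, within 500 nM to 3500 nM, which would mean an estimated step of a 3.3-fold higher number from compound 3 to compound 4 (0.52 log units; beyond the scatter).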

Compound 4, half-maximal inhibitory concentration: 52600 nM
Estimate against measurement, compound 4: 40-fold (1.61 log units) below; the measured number lies above the stated range.
By their numbers in this assay, from the lowest: compound 3; then compounds 2 and 1 (each within the scatter of the next); then compound 4.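

In this assay, the aryl ring on the carbon with a double bond to nitrogen proves far more influential than the first three compounds suggested: there is a 130-fold higher number from compound 3 to compound 4 (2.13 log units; beyond the scatter), and also a 55-fold higher number from compound 2 to compound 4 (1.74 log units; beyond the scatter), which sets the 2,4-dihydroxyphenyl ring well apart from both halogen-bearing rings. Having a hydroxyl group on this ring is not enough by itself to produce a loss of this size, since compound 1 also carries one on its 4-hydroxy-3,5-dimethylphenyl ring, yet the data show a 43-fold higher number from compound 1 to compound 4 (1.63 log units; beyond the scatter). No measurement in hand gives a cause for this sharp loss of potency.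

The compounds shown leave open whether the loss requires both hydroxyl groups or would appear with only one of them. Rings carrying methoxy groups, amino groups or bromine atoms in the same place would show whether the weak result is specific to the free hydroxyl groups or extends to other replacements for the chlorines.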